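Butyl to tert-butyl on a carbonyl carbon

The source may report more compounds than this note shows. Statements on the series, on what has been measured and on what is new or still open speak of the compounds shown alone.

In a physicochemical assay for metabolic stability, at pH 8, in the presence of a further agent that is not named here (on this read-out higher numbers stand for a longer-lived compound and lower numbers for a shorter-lived compound), compound 2 `CCCCC(=O)OC[C@@H]1OC[C@H](n2cc(C)c(=O)[nH]c2=O)O1` gives 0.308 h and compound 1 `Cc1cn([C@H]2CO[C@@H](COC(=O)C3CCCCC3)O2)c(=O)[nH]c1=O` gives 0.322 h, so the two stand within the scatter of each other. Compound 3 `Cc1cn([C@H]2CO[C@@H](COC(=O)C(C)(C)C)O2)c(=O)[nH]c1=O` keeps the shared core and differs in one group: tert-butyl in place of butyl on a carbonyl carbon. Among the measured compounds shown here, only one measured step bears on this, a 1.0-fold lower number from compound 1 to compound 2 (0.02 log units; within the scatter), with butyl in place of cyclohexyl on a carbonyl carbon. That step is small, but it involves no tert-butyl group, so the data hold no direct test of this change. A modest move toward a longer half-life is expected, although a result within the scatter remains possible. The expected step is a 2.3-fold higher number from compound 2 to compound 3 (0.36 log units; beyond the scatter). In this assay the estimate for compound 3 is 0.7 h, with an expected range from 0.3 h to 2.5 h.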

Compound 3, half-life: 0.283 h
Beside the measured number, compound 3's estimate is 2.5-fold (0.39 log units) above it; the whole stated range lies above it.
By their numbers in this assay, from the lowest: compounds 3, 2 and 1 (each within the scatter of the next).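

In this assay, among the compounds shown here, tert-butyl on the carbonyl carbon gives the first test of this group at this position, and it yields a 1.1-fold lower number from compound 2 to compound 3 (0.04 log units; within the scatter) and a 1.1-fold lower number from compound 1 to compound 3 (0.06 log units; within the scatter). Cyclohexyl, butyl and tert-butyl therefore all stand within the scatter of one another here, so among these three compounds the choice of group on the carbonyl carbon does not separate the half-lives. No measurement at hand accounts for this sameness.

All three groups contain carbon alone, so it remains open whether a group carrying an amine or a carboxylic acid would give a half-life beyond the scatter of these compounds. On these data alone, it is equally open whether a longer chain on the same carbonyl carbon would do so.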